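Methylamino in place of dimethylamino on compound 1

The compounds below may be only part of what the source reports. "The series", "measured", "known", "first", "only" and "open" are said of these compounds alone.

In an ADME assay on microsomes from liver (Mus musculus) for metabolic stability, read by HPLC, with a stated time of 4 h (a higher number here means faster removal of the compound, a lower number slower removal), compound 1 `CN(C)c1ccc2cc(-c3cc(Cl)cc(Cl)c3)c(N)nc2c1` gives 210 mL/min/kg. Compound 2 `CN(C)c1ccc2cc(-c3nc4ccccc4s3)c(N)nc2c1` gives 280 mL/min/kg, and the two values lie within the scatter of each other. Compound 3 `CNc1ccc2cc(-c3cc(Cl)cc(Cl)c3)c(N)nc2c1` keeps the core of compound 1 and changes dimethylamino to methylamino, with hydrogen in place of methyl on a nitrogen on an aromatic ring. Among the compounds with values here, no measured pair shows this change, so no step beyond the scatter is expected in this assay. The estimated change is a 1.1-fold lower number from compound 1 to compound 3 (0.04 log units; within the scatter). For compound 3 the expected value is 190 mL/min/kg, with an estimated range of 100 mL/min/kg to 340 mL/min/kg.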

Compound 3, clearance: < 10 mL/min/kg
Compound 3: a limit, no number (the forecaster's own chance of this, stated with the estimate: 3%); middle value at least 19-fold (1.27 log units) away from the limit.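

Hydrogen in place of methyl on a nitrogen on an aromatic ring gives an at least 21-fold lower number from compound 1 to compound 3 (1.32 log units; beyond the scatter) in this assay, so this one position carries a large step that compounds 1 and 2, both dimethylamino, could not show. Compound 3 gives a limit, not a number: the limit of < 10 mL/min/kg in this assay, at which 1 of the 3 values shown sits. The step is read on the core of compound 1 only.

From the compounds shown here alone, whether the same change holds on compound 2 stays open. So does whether an unsubstituted amino group or ethylamino at this nitrogen would follow methylamino.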